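Moving the fluorine on the indazole of compound 3

The source may report more compounds than this note shows. Statements on the series, on what has been measured and on what is new or still open speak of the compounds shown alone.

Compound 1 `CC/C(=C(/c1ccc(/C=C/C(=O)O)cc1)c1cc2cn[nH]c2cn1)c1ccccc1` gives 442 nM in a functional assay on MCF7 cells (Homo sapiens) for cytotoxicity, read by CellTiter-Glo, with a stated time of 5 days; on this read-out higher numbers stand for weaker inhibition and lower numbers for stronger inhibition.
Compound 2 `CC/C(=C(/c1ccc(/C=C/C(=O)O)cc1)c1cc2cn[nH]c2cc1C)c1ccccc1` gives 468 nM in this assay.
Compound 3 `CC/C(=C(/c1ccc(/C=C/C(=O)O)cc1)c1ccc2[nH]nc(F)c2c1)c1ccccc1` gives 5 nM in this assay.

Compound 3 has the lowest number of the three measured compounds, so it inhibits MCF7 cell growth most strongly; compound 1 and compound 2 sit far above it, and those two lie within the scatter of each other.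

Compound 4 `CC/C(=C(/c1ccc(/C=C/C(=O)O)cc1)c1ccc2[nH]ncc2c1F)c1ccccc1` is the next compound. The change from compound 3 is 4-fluoro-1H-indazol-5-yl in place of 3-fluoro-1H-indazol-5-yl on a double-bonded chain carbon bound to an aromatic carbon and a double-bonded chain carbon; the two compounds share every atom, and only the point where the fluorine sits on the indazole moves from the five-membered ring to the six-membered ring.

Among the compounds with values here, no measured step moves a fluorine in this way. The nearest guide is a 94-fold lower number from compound 2 to compound 3 (1.97 log units; beyond the scatter), together with an 88-fold lower number from compound 1 to compound 3 (1.95 log units; beyond the scatter): both show that what sits on the ring attached to the double-bonded chain carbon can shift the number very strongly. Within the data shown here, that makes a wide range of outcomes plausible for compound 4, and a change as small as the one from compound 1 to compound 2 cannot be assumed.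

The expectation for compound 4 in this assay is a modest loss, a 4.0-fold higher number from compound 3 to compound 4 (0.60 log units; beyond the scatter), giving an estimated 20 nM with a range from 4 nM to 150 nM.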

Compound 4, half-maximal inhibitory concentration: 3 nM
Beside the measured number, compound 4's estimate is 6.7-fold (0.82 log units) above it, and the stated range ends above it.
By their numbers in this assay, from the lowest: compounds 4 and 3 (each within the scatter of the next); then compounds 1 and 2 (each within the scatter of the next).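

In this assay, 4-fluoro-1H-indazol-5-yl in place of 3-fluoro-1H-indazol-5-yl gives a 1.7-fold lower number from compound 3 to compound 4 (0.22 log units; within the scatter), so the low number seen earlier does not depend on the fluorine sitting at the one point it held before. Both fluorinated groups stand far from the two earlier groups: 4-fluoro-1H-indazol-5-yl in place of 6-methyl-1H-indazol-5-yl gives a 160-fold lower number from compound 2 to compound 4 (2.19 log units; beyond the scatter), and in place of the group with a hetero atom in its six-membered ring it gives a 150-fold lower number from compound 1 to compound 4 (2.17 log units; beyond the scatter), steps as large as those already seen with the 3-fluoro group. No measurement at hand explains why the two fluorine placements read alike or why both differ so strongly from the other groups.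

Still open, from the compounds shown here alone, is whether a fluorine is needed at all, a question that the plain 1H-indazol-5-yl group, or a chlorine or a methoxy group in the fluorine's place, would answer. Also open, going by these compounds, is how the other fluorine placements on the indazole would read, and whether these low numbers would hold with an amide in place of the carboxylic acid.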